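Benzylamino nucleosides and cytotoxicity toward mouse fibroblasts

A few compounds are considered here, and "the series" means these few. Any claim that something is new, unique, unknown or untested is made for them only; others in the source may bear on it.

Measured compounds:
- compound 1, `OC[C@H]1O[C@@H](n2cnc3c(NCc4cccc(Br)c4)ncnc32)[C@H](O)[C@@H]1O`: > 166000 nM
- compound 2, `Cc1ccc(CNc2ncnc3c2ncn3[C@@H]2O[C@H](CO)[C@@H](O)[C@H]2O)cc1`: > 166000 nM
- compound 3, `COc1ccc(CNc2ncnc3c2ncn3[C@@H]2O[C@H](CO)[C@@H](O)[C@H]2O)c(OC)c1`: "not determined" (no result reported)

In an ADME assay on NIH3T3 cells (Mus musculus) for cytotoxicity, with a stated time of 72 h (on this read-out higher numbers stand for weaker inhibition and lower numbers for stronger inhibition), compound 1 reaches only a limit of the test, > 166000 nM. Compound 2 likewise gives only a limit there, > 166000 nM. For compound 3 no result was recorded. Compound 1 therefore stands at the limit of > 166000 nM in this assay, at which 2 of the 3 values shown sit, and the step that the two limits leave unreadable from compound 1 to compound 2 cannot be read in size. The new compound 4, `OC[C@H]1O[C@@H](n2cnc3c(NCc4ccc(F)cc4Cl)ncnc32)[C@H](O)[C@@H]1O`, differs from compound 1 by 2-chloro-4-fluorophenyl in place of 3-bromophenyl on a saturated chain carbon bound to a nitrogen on an aromatic ring. Within the data shown here, no measured step shows a readable change for a swap of this kind, so no movement beyond the scatter is expected for a step that the limit leaves unreadable from compound 1 to compound 4 in this assay. Compound 4 is estimated at 200000 nM, within 100000 nM to 400000 nM, most likely again reported as a limit.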

Compound 4, half-maximal inhibitory concentration: > 166000 nM
Compound 4: only a limit was reported; the forecaster's own chance of this, stated with the estimate: 80%; the middle value is on the limit's open side.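

Compound 4 also gives only a limit in this assay, so its steps from compound 1 and compound 2 cannot be read in size: the limit of > 166000 nM in this assay, at which 3 of the 4 values shown sit.

Going by these compounds, whether changing the benzyl group alters cytotoxicity at all remains open.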